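The compounds below may be only part of what the source reports. "The series", "measured", "known", "first", "only" and "open" are said of these compounds alone.

Compound 2 `CC(=O)Nc1ccc(C/N=C(\S)NCC(COC(=O)C(C)(C)C)Cc2ccc(C)c(C)c2)cc1` — 450 nM in a functional assay on CHO cells with transient receptor potential cation channel subfamily V member 1 (Rattus norvegicus) as the target; on this read-out higher numbers stand for an effect only at larger amounts of compound and lower numbers for an effect already at smaller amounts
Compound 1 `COc1cc(CNC(=S)NCC(COC(=O)C(C)(C)C)Cc2ccc(C)c(C)c2)ccc1O` — 1.97 nM in this assay

Of the two measured compounds, compound 2 gives the higher number in this assay, and compound 1 sits far lower, a gap beyond the scatter. Compound 3 `Cc1ccc(CC(CN/C(S)=N/Cc2cccc(NS(C)(=O)=O)c2)COC(=O)C(C)(C)C)cc1C` is not yet measured; it carries 3-(methanesulfonamido)phenyl in place of 4-acetamidophenyl on a saturated chain carbon bound to a double-bonded nitrogen. For the measured compounds named here, no measured pair traces this change, so the expectation rests on the two values alone. The step from compound 2 to compound 3 is expected to be a moderate drop, a 3.8-fold lower number from compound 2 to compound 3 (0.57 log units; beyond the scatter), beyond the scatter. Compound 3 is therefore estimated at 120 nM in this assay, with a range from 25 nM to 600 nM.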

Compound 3, half-maximal effective concentration: 990 nM
For compound 3 the middle estimate is 8.3-fold (0.92 log units) below the measured one; the whole stated range lies below it.
By their numbers in this assay, from the lowest: compound 1; then compound 2; then compound 3.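

In this assay, 3-(methanesulfonamido)phenyl in place of 4-acetamidophenyl gives a 2.2-fold higher number from compound 2 to compound 3 (0.34 log units; beyond the scatter) and so a modest step, not a return towards compound 1, which stays at 1.97 nM in the same read-out. This position therefore takes a second group with little movement of the number, at least across these two groups. No evidence on the cause of this step is at hand.

Since the two names differ in both the group and its number, the shown compounds cannot separate those two changes. Going by these compounds, how 3-acetamidophenyl, 4-(methanesulfonamido)phenyl or a simple aminophenyl would read here remains open.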